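Chloro for fluoro in the anilino ring of the shared core

The compounds below may be only part of what the source reports. "The series", "measured", "known", "first", "only" and "open" are said of these compounds alone.

Measured compounds in this set:
compound 1 `CN1CCN(CCCOc2cccc3nc(Nc4ccc(F)c(F)c4)ccc23)CC1` with 9090 nM
compound 2 `CN1CCN(CCCOc2cccc3nc(Nc4cccc(Cl)c4)ccc23)CC1` with 4000 nM

Both were tested in a functional assay on cells (Panel CNS (Carcinoma cell lines), Homo sapiens) for inhibition, read by sulforhodamine B assay, with a stated time of 48 h; a higher number here means a weaker inhibitor of growth, a lower number a stronger inhibitor of growth. Compound 1 gives the highest of the two numbers; the nearest is compound 2, reached by a 2.3-fold lower number from compound 1 to compound 2 (0.36 log units; beyond the scatter), a modest but real drop in the number when 3-chlorophenyl stands in place of 3,4-difluorophenyl on the nitrogen attached to the core.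

The next compound is compound 3 `CN1CCN(CCCOc2cccc3nc(Nc4ccc(Cl)c(F)c4)ccc23)CC1`, not yet measured. Its difference from compound 1 is chloro in place of fluoro on an aromatic carbon: the chloro enters on an aromatic carbon of a six-membered aromatic ring of carbon only, ortho to a fluoro group and para to a large group, so that the ring reads 4-chloro-3-fluorophenyl rather than 3,4-difluorophenyl.

Among the measured compounds shown here, the only step that bears on this is the one from compound 1 to compound 2, which swaps both fluoro groups for a single chloro and is therefore not the same change. Still, that step gave a lower number, and the expectation for compound 3 is a step of similar direction and size, a 1.7-fold lower number from compound 1 to compound 3 (0.22 log units; within the scatter), in this assay. Compound 3 is thus estimated at 5500 nM, with a range from 2500 nM to 12000 nM.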

Compound 3, concentration for total growth inhibition: 3350 nM
Compound 3: the middle estimate sits 1.6-fold (0.22 log units) above what was measured; measured number inside the range.
By their numbers in this assay, from the lowest: compounds 3 and 2 (each within the scatter of the next); then compound 1.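

In this assay, chloro in place of fluoro on an aromatic carbon, para to a large group and ortho to a fluoro group, gives a 2.7-fold lower number from compound 1 to compound 3 (0.43 log units; beyond the scatter) and so shows that this position responds to the exchange of one halogen alone, something the earlier step could not separate, since both fluoro groups left in it. The 3-chlorophenyl and 4-chloro-3-fluorophenyl groups cannot be told apart here, with a 1.2-fold lower number from compound 2 to compound 3 (0.08 log units; within the scatter) and thus no gain or loss to read from adding the fluoro group to a chloro-bearing ring, so among these three compounds both chloro compounds, compound 2 and compound 3, sit lower than the difluoro compound 1, although the chloro stands at a different place on the ring in each. Nothing accompanying these numbers bears on why the exchange changes the read-out.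

The compounds shown leave open whether bromo, methyl or trifluoromethyl at the same position would follow chloro or fluoro. They also leave open what a 4-chlorophenyl group would give, which would show whether the remaining fluoro group matters at all.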